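Methoxy on the benzyl ring of the bis(trifluoromethyl)sulfonamides

A few compounds are considered here, and "the series" means these few. Any claim that something is new, unique, unknown or untested is made for them only; others in the source may bear on it.

Compound 3 `O=S(=O)(NCCCNCc1ccccc1)c1cc(C(F)(F)F)cc(C(F)(F)F)c1` gives 14000 nM in a functional assay on Capan-2 cells (Homo sapiens) for inhibition, read by MTT assay, with a stated time of 72 h (a lower number here means a stronger inhibitor of growth, a higher number a weaker inhibitor of growth), the highest number of the three measured. Compound 1 `O=S(=O)(NCCCCNCc1ccc(Br)cc1)c1cc(C(F)(F)F)cc(C(F)(F)F)c1` gives 1900 nM and compound 2 `O=S(=O)(NCCCNCc1ccc(Cl)c(Cl)c1)c1cc(C(F)(F)F)cc(C(F)(F)F)c1` gives 1800 nM; these two sit together, a 1.1-fold lower number from compound 1 to compound 2 (0.02 log units; within the scatter). Both steps into compound 3 raise the number: a 7.4-fold higher number from compound 1 to compound 3 (0.87 log units; beyond the scatter) and a 7.8-fold higher number from compound 2 to compound 3 (0.89 log units; beyond the scatter). Compound 4 `COc1ccccc1CNCCCNS(=O)(=O)c1cc(C(F)(F)F)cc(C(F)(F)F)c1` differs from compound 3 by methoxy in place of hydrogen on an aromatic carbon, placed on an aromatic carbon ortho to a large group. Within the data shown here, no measured step covers a methoxy group or this position; the steps that bear on this ring show only that halogen substitution gives lower numbers. A modest drop in the number is therefore expected, with wide uncertainty. Compound 4 is estimated at 8000 nM, range 3000 nM to 20000 nM, an expected step of a 1.8-fold lower number from compound 3 to compound 4 (0.24 log units; within the scatter).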

Compound 4, concentration for 50% growth inhibition: 6000 nM
Compound 4: middle estimate off by 1.3-fold (0.12 log units), on the high side; low and high end bracket the measured number.
By their numbers in this assay, from the lowest: compounds 2 and 1 (each within the scatter of the next); then compound 4; then compound 3.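

Methoxy, a group that is not a halogen, also lowers the number in this assay when placed on an aromatic carbon ortho to a large group (a 2.3-fold lower number from compound 3 to compound 4 (0.37 log units; beyond the scatter)). This gain stops short of the halogen-bearing compounds, as the 2-methoxybenzyl compound still gives the higher number (a 3.3-fold higher number from compound 2 to compound 4 (0.52 log units; beyond the scatter); a 3.2-fold higher number from compound 1 to compound 4 (0.50 log units; beyond the scatter)). No measurement available here accounts for this step. Open, going by these compounds, is whether ethoxy or hydroxyl at this position would lower the number further. Also open, on these data alone, is how methoxy behaves elsewhere on the ring, or with a longer chain.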